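A few compounds are considered here, and "the series" means these few. Any claim that something is new, unique, unknown or untested is made for them only; others in the source may bear on it.

In an ADME assay on RAW264.7 cells (Mus musculus) for cytotoxicity, read by MTT assay (on this read-out lower numbers stand for stronger inhibition and higher numbers for weaker inhibition), measured so far:
- compound 1 `COc1cc(/C=C/c2nc(Nc3ccc(C(F)(F)F)cc3)c3sccc3n2)cc(OC)c1OC`: > 50000 nM (a limit)
- compound 2 `COc1cc(/C=C/c2nc(Nc3ccc(O)cc3)c3sccc3n2)cc(OC)c1OC`: > 50000 nM (a limit)

Compound 2 gives no number on this read-out, only > 50000 nM, which is a limit. The same holds for the other measured compound: the limit of > 50000 nM in this assay, at which 2 of the 2 values shown sit.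

Compound 3 `COc1ccc(CNc2nc(/C=C/c3cc(OC)c(OC)c(OC)c3)nc3ccsc23)cc1` differs from compound 2 as follows: 4-methoxybenzyl in place of 4-hydroxyphenyl on a nitrogen on an aromatic ring. This places 4-methoxybenzyl in place of 4-hydroxyphenyl on a nitrogen on an aromatic ring.

Among the compounds with values here, the only measured step is a step that the two limits leave unreadable from compound 1 to compound 2. It changes a different group and has no readable size, so it offers no size or direction for this change. No step beyond the scatter is therefore expected in this assay, and the expectation rests on the limit value of compound 2, > 50000 nM.

The expected step is a number no higher from compound 2 to compound 3 (the limit leaves the size open). For compound 3 the estimate is 50000 nM, with an expected range of 15000 nM to 100000 nM.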

Compound 3, half-maximal inhibitory concentration: > 50000 nM
Compound 3: only a limit was reported (the forecaster's own chance of this, stated with the estimate: 75%); the middle value lies on the limit itself.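

No new step can be read among compound 1, compound 2 and compound 3: in this assay, compound 3 gives > 50000 nM, which is a limit. The compounds shown leave open whether any group on the nitrogen changes this read-out, because all of them share one limit: the limit of > 50000 nM in this assay, at which 3 of the 3 values shown sit.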